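The compounds below may be only part of what the source reports. "The series", "measured", "known", "first", "only" and "open" are said of these compounds alone.

Three compounds have been measured in a functional assay on HCT-116 cells (Homo sapiens) for antiproliferative activity, read by MTT assay, with a stated time of 72 h; a higher number here means a weaker inhibitor, a lower number a stronger inhibitor:

compound 1, `Nc1nc(N)c2cc(CSC(=S)N3CCN(c4ccccc4)CC3)ccc2n1`, gives 4120 nM
compound 2, `Nc1nc(N)c2cc(CSC(=S)N3CCN(c4ccc(O)cc4)CC3)ccc2n1`, gives 5980 nM
compound 3, `Cc1ccc(N2CCN(C(=S)SCc3ccc4nc(N)nc(N)c4c3)CC2)c(C)c1`, gives 4070 nM

Compound 3 shows the lowest number of the three, but both steps that lead to it are small: a 1.0-fold lower number from compound 1 to compound 3 (0.01 log units; within the scatter), and a 1.5-fold lower number from compound 2 to compound 3 (0.17 log units; within the scatter), so the three compounds cannot be told apart. The step from compound 1 to compound 2 is likewise a 1.5-fold higher number from compound 1 to compound 2 (0.16 log units; within the scatter).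

Compound 4, `Nc1nc(N)c2cc(CSC(=S)N3CCN(c4ncccn4)CC3)ccc2n1`, differs from compound 3 in one place: pyrimidin-2-yl in place of 2,4-dimethylphenyl on an amine nitrogen in a ring. Among the measured compounds shown here, no measured step exchanges an aryl ring for a heteroaryl ring at this position, so none bears on it directly. What the three measured steps do show is that changing the group on the ring nitrogen, whether by adding a hydroxy or by adding two methyls, left the number within the scatter each time. On that basis no step beyond the scatter is expected in this assay from compound 3 to compound 4.

Compound 4 is therefore estimated at 4500 nM, with a range from 2000 nM to 10000 nM, which corresponds to an expected step of a 1.1-fold higher number from compound 3 to compound 4 (0.04 log units; within the scatter).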

Compound 4, half-maximal inhibitory concentration: 5840 nM
Compound 4: the middle estimate sits 1.3-fold (0.11 log units) below what was measured; low and high end bracket the measured number.
By their numbers in this assay, from the lowest: compounds 3, 1, 4 and 2 (each within the scatter of the next).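

In this assay three steps now reach the pyrimidin-2-yl group from rings of carbon only: a 1.4-fold higher number from compound 3 to compound 4 (0.16 log units; within the scatter) and a 1.4-fold higher number from compound 1 to compound 4 (0.15 log units; within the scatter) and a 1.0-fold lower number from compound 2 to compound 4 (0.01 log units; within the scatter) all stay within the scatter. At this position, on an amine nitrogen in a ring, a six-membered aromatic ring with 2 hetero atoms therefore cannot be told apart from the phenyl, 4-hydroxyphenyl or 2,4-dimethylphenyl groups, and the four compounds remain indistinguishable in this read-out. Nothing measured here offers an explanation for this result.

The compounds shown leave open whether a benzyl or acetyl group on this ring nitrogen, or an aromatic ring bearing an amine or a carboxylic acid, would move the number beyond the scatter. On these data alone, whether a change elsewhere in the shared core would do so also stays open.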